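A few compounds are considered here, and "the series" means these few. Any claim that something is new, unique, unknown or untested is made for them only; others in the source may bear on it.

The three measured compounds are compound 1 `COc1ccc(/C=C/C(=O)CC(C)=O)cc1` with 18700 nM, compound 2 `COc1ccc(/C=C/c2cc(C)no2)cc1` with 58300 nM, and compound 3 `Cc1cc(/C=C/c2ccc(O)cc2)on1` with 50200 nM, all in an ADME assay on HEK293 cells (Homo sapiens) for cytotoxicity, read by MTT assay, with a stated time of 72 h; a lower number here means a stronger inhibitor, a higher number a weaker inhibitor.

Compound 2 and compound 3 differ by one change, (hydrogen in place of methyl on an oxygen on an aromatic ring), and it produced a 1.2-fold lower number from compound 2 to compound 3 (0.06 log units; within the scatter). The same change, (hydrogen in place of methyl on an oxygen on an aromatic ring), turns compound 1 into the unmeasured compound 4 `CC(=O)CC(=O)/C=C/c1ccc(O)cc1`. The cores of compound 1 and compound 2 are not the same, and the difference between the two cores is not broken down here; their values show compound 1 with the lower number of the two.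

For compound 4 the expected step from compound 1 is a 1.2-fold lower number from compound 1 to compound 4 (0.07 log units; within the scatter), resting on the earlier 1.2-fold lower number from compound 2 to compound 3 (0.06 log units; within the scatter) in this assay, which stayed within the scatter. Compound 4 is therefore estimated at 16000 nM, expected to lie between 6000 nM and 40000 nM.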

Compound 4, half-maximal inhibitory concentration: 10300 nM
Estimate against measurement, compound 4: 1.6-fold (0.19 log units) above, and the stated range covers the measured number.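

In this assay, changing methoxy to hydroxy on the core of compound 1 gives a 1.8-fold lower number from compound 1 to compound 4 (0.26 log units; within the scatter). Set beside the earlier case, the change reads alike on both cores: the same change on two cores in this assay, a 1.2-fold lower number (0.06 log units; within the scatter) from compound 2 to compound 3 and a 1.8-fold lower number (0.26 log units; within the scatter) from compound 1 to compound 4, 1.6-fold (0.19 log units) apart, within the scatter of two such steps. This shows that, on these two cores, the change gave no step beyond the usual scatter, but it does not show the same for any third core, and neither step stands clear enough of the scatter to reveal a real effect that could carry over.

The compounds shown leave open what a longer chain, such as ethyl in place of the methyl on that oxygen, would do. They also leave open what an amine in place of the hydroxy would do.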